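The compounds below may be only part of what the source reports. "The series", "measured", "known", "first", "only" and "open" are said of these compounds alone.

For the measured compounds named here, in a functional assay for antagonist activity at thromboxane A2 receptor (Rattus norvegicus) (on this read-out lower numbers stand for tighter binding and higher numbers for weaker binding), compound 2 `CS(=O)(=O)Nc1ccccc1-c1ccc(COC2CC[C@H](N3CCCCCC3)[C@H]2OC/C=C\CCC(=O)O)cc1` gives 3.98 nM, the lower of the two numbers so far. Going by the values given here, compound 1 `NC(=O)c1ccccc1-c1ccc(COC2CC[C@H](N3CCCCCC3)[C@H]2OC/C=C\CCC(=O)O)cc1` gives 15.9 nM in this assay, and the only measured step, a 4.0-fold lower number from compound 1 to compound 2 (0.60 log units; beyond the scatter), exchanges the group itself rather than its ring position. Compound 3 `CS(=O)(=O)Nc1cccc(-c2ccc(COC3CC[C@H](N4CCCCCC4)[C@H]3OC/C=C\CCC(=O)O)cc2)c1` differs from compound 2 by 3-(methanesulfonamido)phenyl in place of 2-(methanesulfonamido)phenyl on an aromatic carbon. Among the compounds with values here, no measured step covers this kind of change, so the expected step is small and uncertain in direction, with a slight weakening allowed for, a 1.5-fold higher number from compound 2 to compound 3 (0.18 log units; within the scatter). Compound 3 is therefore estimated at 6 nM, in the range 1.5 nM to 25 nM.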

Compound 3, dissociation constant: 50.1 nM
Estimate against measurement, compound 3: 8.4-fold (0.92 log units) below, outside the stated range (above it).
By their numbers in this assay, from the lowest: compound 2; then compound 1; then compound 3.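

Ring position alone carries much of the effect in this assay: with the same atoms and the same counted donors and acceptors, 3-(methanesulfonamido)phenyl in place of 2-(methanesulfonamido)phenyl gives a 13-fold higher number from compound 2 to compound 3 (1.10 log units; beyond the scatter) in this series. The advantage of 2-(methanesulfonamido)phenyl over 2-carbamoylphenyl does not carry over to the shifted group, since 3-(methanesulfonamido)phenyl in place of 2-carbamoylphenyl gives a 3.2-fold higher number from compound 1 to compound 3 (0.50 log units; beyond the scatter) here. No evidence available bears on this result. Open, from the compounds shown here alone, is whether 3-carbamoylphenyl shows a comparable shift, and how 2-aminophenyl or 2-carboxyphenyl would compare.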